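The compounds below may be only part of what the source reports. "The series", "measured", "known", "first", "only" and "open" are said of these compounds alone.

Measured so far:
- compound 1, `CC(c1ccc(-c2ccccc2)c(F)c1)c1nnc2n1N=C(c1ccc(C(F)(F)F)cc1)CS2`: 9400 nM
- compound 2, `CC(C)Cc1ccc(C(C)c2nnc3n2N=C(c2ccc(Cl)cc2Cl)CS3)cc1`: 7500 nM

Both were run in a functional assay on Huh-7 cells (Homo sapiens) for inhibition, read by sulforhodamine B assay, with a stated time of 72 h; a lower number here means a stronger inhibitor, a higher number a weaker inhibitor. In this assay compound 1 gives 9400 nM and compound 2 gives 7500 nM. Compound 2 has the lowest of the two numbers, but the gap to compound 1 lies within the scatter, so the two cannot be ordered on these figures alone. Within the data shown here, no pair of measured compounds differs in one place only, so no single-change step is available.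

Compound 3, `CC(C)Cc1ccc(C(C)c2nnc3n2N=C(c2ccc(F)cc2)CS3)cc1`, has not yet been measured in this assay. It differs from compound 2 in one place:

4-fluorophenyl in place of 2,4-dichlorophenyl on a carbon with a double bond to nitrogen

Nothing measured in the series isolates this change. The two measured aryl groups on that carbon, trifluoromethylphenyl in compound 1 and 2,4-dichlorophenyl in compound 2, give numbers within the scatter of each other, which offers no ground for a large effect from another aryl on the same carbon. The step from compound 2 to compound 3 is therefore expected to be small, a 1.6-fold higher number from compound 2 to compound 3 (0.20 log units; within the scatter), and of uncertain direction, with a slight lean toward a higher number. For compound 3 in this assay the estimate is 12000 nM, within 5000 nM to 30000 nM.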

Compound 3, half-maximal inhibitory concentration: 7800 nM
For compound 3 the middle estimate is 1.5-fold (0.19 log units) above the measured one; the measured number falls inside the stated range.
By their numbers in this assay, from the lowest: compounds 2, 3 and 1 (each within the scatter of the next).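

In this assay, among these compounds, the single-place step gives a 1.0-fold higher number from compound 2 to compound 3 (0.02 log units; within the scatter), the first direct reading at this position: on a carbon with a double bond to nitrogen, 4-fluorophenyl and 2,4-dichlorophenyl cannot be told apart. Compound 1 and compound 2 differ in more than one place and could not isolate this position, whereas this pair shows that exchanging two chlorine atoms for one fluorine on the phenyl ring, with one heavy atom fewer in the group, leaves the two numbers within the scatter. No supporting measurement bears on why these two aryl groups read alike.

Only halogen-bearing or trifluoromethyl-bearing phenyl groups are shown on this carbon, so it remains open whether a phenyl ring carrying an amine or a carboxylic acid, or a pyridine ring in its place, would also stay within the scatter. Among the compounds shown here, the other aryl group on the shared core also has no single-place step, which leaves the reading of a longer chain or an amine there open as well.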